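Series notes: from compound 3 to compound 4

The source may report more compounds than this note shows. Statements on the series, on what has been measured and on what is new or still open speak of the compounds shown alone.

Compound 3 `O=[N+]([O-])c1cccc(CNc2cc(C(F)(F)F)cc3[nH]ncc23)c1` gives in an assay for inhibition of Indoleamine 2,3-dioxygenase 1 (Homo sapiens), with stated times of 10 min and 60 min (on this read-out lower numbers stand for stronger inhibition and higher numbers for weaker inhibition), only a limit, > 100000 nM. Compound 1 `Nc1cccc(CNc2cc(C(F)(F)F)cc3[nH]ncc23)c1` likewise reaches only a limit in this assay, > 100000 nM. Compound 2 `O=C1NCc2c(NCc3ccccc3[N+](=O)[O-])cccc21` also gives only a limit in this assay, > 100000 nM. For the measured compounds named here, the single one-point step measured, a step that the two limits leave unreadable from compound 1 to compound 3, runs between two limits and cannot be read. Going by the values given here, what the numbers show is summed up by the limit of > 100000 nM in this assay, at which 3 of the 3 values shown sit: every value so far sits at the same limit, so no direction of change has yet been seen.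

Compound 4 `O=C(O)CNc1cccc(CNc2cc(C(F)(F)F)cc3[nH]ncc23)c1` differs from compound 3 by (carboxymethyl)amino in place of nitro on an aromatic carbon. Among the compounds with values here, no measured step bears on this change, and the step from compound 1 to compound 3 gives no size to carry over. With nothing to move it, compound 4 is expected to stay near the limit, estimated at 100000 nM with a range from 20000 nM to 500000 nM. The expected step is a number no higher from compound 3 to compound 4 (the limit leaves the size open), which is taken as none beyond the scatter, with a limit again the most likely outcome.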

Compound 4, half-maximal inhibitory concentration: > 100000 nM
Compound 4 ended at the assay's limit (the forecaster's own chance of this, stated with the estimate: 80%); the middle value lies on the limit itself.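

In this assay compound 4 gives only a limit of > 100000 nM and the steps to it from compound 1 and compound 3 cannot be read. The compounds shown leave open which change, if any, would bring a value off this limit: the limit of > 100000 nM in this assay, at which 4 of the 4 values shown sit.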